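A few compounds are considered here, and "the series" means these few. Any claim that something is new, unique, unknown or untested is made for them only; others in the source may bear on it.

In a functional assay on L1210 cells (Mus musculus) for inhibition (on this read-out lower numbers stand for stronger inhibition and higher numbers for weaker inhibition), compound 1 (`COC(=O)c1ccc(OC)c(C/C=C(\C)CCC(=O)O)c1O`) gives > 100000 nM, which is a limit of the assay. Compound 2 (`COc1ccc(C(N)=O)c(O)c1C/C=C(\C)CCC(=O)O`) gives > 100000 nM, also a limit. The data therefore show (the limit of > 100000 nM in this assay, at which 2 of the 2 values shown sit). Compound 3 (`COc1ccc(C(C)=O)c(O)c1C/C=C(\C)CCC(=O)O`) differs from compound 1 by methyl in place of methoxy on a carbonyl carbon, with methyl in place of methoxy on a carbonyl carbon. Going by the values given here, the only measured step at this place, a step that the two limits leave unreadable from compound 1 to compound 2, offers no size or direction to carry over. The expected step, a number no higher from compound 1 to compound 3 (the limit leaves the size open), is therefore none beyond the scatter in this assay. Compound 3 is expected at 100000 nM, with an estimated range from 30000 nM to 300000 nM.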

Compound 3, half-maximal inhibitory concentration: > 100000 nM
Compound 3: a limit, no number (the forecaster's own chance of this, stated with the estimate: 80%); the middle value lies on the limit itself.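

Compound 3 gives > 100000 nM in this assay, which is a limit of the assay, so its steps from compound 1 and compound 2 cannot be read: the limit of > 100000 nM in this assay, at which 3 of the 3 values shown sit.

The compounds shown leave open whether any group on the carbonyl carbon changes inhibition in this assay.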